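Working notes: chloro removal across compounds 1 to 4

The source may hold more compounds than are shown below. What is called first, only, known or untested is meant among the compounds shown, and "the series" means these compounds.

Measured in an assay on cells for antagonist activity at P2X purinoceptor 7 (Homo sapiens), read by fluorescence and calcium flux, with a stated time of 30 min; a lower number here means a stronger inhibitor, a higher number a weaker inhibitor:
- compound 1, `O=C(Nc1cc(C(F)(F)F)cc(C(F)(F)F)c1)c1ccccc1O`: compound 1 gives 315 nM
- compound 2, `O=C(Nc1cc(C(F)(F)F)cc(C(F)(F)F)c1)c1cccc(Cl)c1O`: compound 2 gives 177 nM
- compound 3, `O=C(Nc1cc(Cl)cc(Cl)c1)c1cc(Cl)ccc1O`: compound 3 gives 70.4 nM

Compound 3 gives the lowest number of the three in this assay; compound 2 is nearest to it and compound 1 furthest, both beyond the scatter. The difference between the cores of compound 2 and compound 3 is not broken down here.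

Compound 2 and compound 1 differ in one place: hydrogen in place of chloro on an aromatic carbon. The step is a 1.8-fold higher number from compound 2 to compound 1 (0.25 log units; within the scatter).

Compound 4, `O=C(Nc1cccc(Cl)c1)c1cc(Cl)ccc1O`, is not yet measured in this assay. It follows from compound 3 by the same kind of change: hydrogen in place of chloro on an aromatic carbon. The surroundings differ: in compound 2 the chloro removed sits ortho to a hydroxy group and meta to a large group, in compound 3 meta to a chloro group and meta to a large group. A modest rise in the number is expected because a 1.8-fold higher number from compound 2 to compound 1 (0.25 log units; within the scatter) stayed within the scatter, but the two places are not the same, so the expected step, a 2.6-fold higher number from compound 3 to compound 4 (0.41 log units; beyond the scatter), is set somewhat larger. Compound 4 is estimated at 180 nM, between 70 nM and 500 nM.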

Compound 4, half-maximal inhibitory concentration: 599 nM
Estimate against measurement, compound 4: 3.3-fold (0.52 log units) below, outside the stated range (above it).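

In this assay, hydrogen in place of chloro gives an 8.5-fold higher number from compound 3 to compound 4 (0.93 log units; beyond the scatter), and the size of this step does not carry over from the earlier core: the same change on two cores in this assay, a 1.8-fold higher number (0.25 log units; within the scatter) from compound 2 to compound 1 and an 8.5-fold higher number (0.93 log units; beyond the scatter) from compound 3 to compound 4, 4.8-fold (0.68 log units) apart, beyond the scatter of two such steps

A step read on one core of this series is therefore no reliable measure of the same change on another core, and the chloro in compound 3 counts for far more than the chloro in compound 2. What this does not show is the source of the gap: the two chloro groups removed do not sit in the same place, and the cores differ elsewhere as well, so these two pairs cannot separate place from surroundings and give no general rule for the series.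

The compounds shown leave open whether a fluoro or a methyl group in place of the chloro removed from compound 3 would hold the number near that of compound 3 or near that of compound 4. They also leave open how a methoxy group or an amine in place of the hydroxy group would act on either core.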